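Moving the pyridine one carbon out on the thiocarbamate nitrogen

The source may report more compounds than this note shows. Statements on the series, on what has been measured and on what is new or still open speak of the compounds shown alone.

Measured compounds:
compound 1 `Nc1ccccc1NC(=O)c1ccc(CSC(=S)N2CCN(c3ccccc3)CC2)cc1` gives 87.4%
compound 2 `CN(C(=S)SCc1ccc(C(=O)Nc2ccccc2N)cc1)c1cccnc1` gives 82.5%

Of the compounds shown here, two have been tested in a functional assay on MGC-803 cells (Homo sapiens) for antiproliferative activity, read by CCK-8 assay, with a stated time of 72 h, tested at 8 uM; a higher number here means a stronger effect of the compound at the concentration tested, a lower number a weaker effect. Compound 1 `Nc1ccccc1NC(=O)c1ccc(CSC(=S)N2CCN(c3ccccc3)CC2)cc1` and compound 2 `CN(C(=S)SCc1ccc(C(=O)Nc2ccccc2N)cc1)c1cccnc1` share the same core, and the reading of compound 2 sits within the usual scatter of the reading of compound 1, so the two numbers cannot be told apart.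

The step followed here leads from compound 2 to compound 3 `CN(Cc1cccnc1)C(=S)SCc1ccc(C(=O)Nc2ccccc2N)cc1`, which has not yet been tested in this assay. The change is (pyridin-3-yl)methyl in place of pyridin-3-yl on an amide-type nitrogen: the pyridin-3-yl group on the amide-type nitrogen is replaced by a (pyridin-3-yl)methyl group, so the ring is carried one saturated carbon further from that nitrogen.

Going by the values given here, no measured pair in this set shows what such a change does, so there is no number to lean on. Both known compounds, compound 1 and compound 2, lie close together, and the change in compound 3 is small in size. The expected step of a number 0.5 percentage points lower from compound 2 to compound 3 (within the scatter) is therefore none beyond the scatter, in either direction. Compound 3 is estimated at 82%, with a range from 68% to 92%.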

Compound 3, a percentage reported as inhibition, at one concentration (the size of the read-out at that concentration, not a potency): 85.5%
Estimate against measurement, compound 3: 3.5 percentage points below; low and high end bracket the measured number.
By their numbers in this assay, from the lowest: compounds 2, 3 and 1 (each within the scatter of the next).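

In this assay, going by these compounds alone, replacing pyridin-3-yl with (pyridin-3-yl)methyl on the amide-type nitrogen gives the first measured step at this position: a number 3 percentage points higher from compound 2 to compound 3 (within the scatter). Carrying the ring one saturated carbon further from that nitrogen therefore leaves no effect that can be told apart from the ordinary spread of repeat measurements, so at this concentration the position tolerates the extra carbon. Nothing measured here explains this outcome, and no supporting data on the properties of these groups are available.

The compounds shown leave open whether a longer chain carrying the pyridin-3-yl group would read the same, and whether an amine or a carboxylic acid in place of that ring would keep the effect. Going by these compounds, each compound also has a reading at only one concentration, which gives the size of the effect and not a potency, so it remains open whether compound 2 and compound 3 would differ across a range of concentrations.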